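A few compounds are considered here, and "the series" means these few. Any claim that something is new, unique, unknown or untested is made for them only; others in the source may bear on it.

Working notes on the series.

Compound 3 `COc1ccc(NC(=O)COc2cc(C)nc3ccc(OC)cc23)cc1` sits at the assay limit in an ADME assay on HepG2 cells (Homo sapiens) for cytotoxicity, read by trypan blue exclusion, with a stated time of 48 h, in the presence of a further agent that is not named here (a lower number here means that less compound is tolerated, a higher number that more compound is tolerated), with a value of > 142000 nM that is a limit and not a number. Compound 1 `COc1ccc2nc(C)cc(OCC(=O)Nc3ccccc3)c2c1` likewise gives a limit, > 155000 nM. Compound 2 `COc1cccc(NC(=O)COc2cc(C)nc3ccc(OC)cc23)c1` gives a measured number, 43000 nM. Of the shown steps, an at least 3.6-fold lower number from compound 1 to compound 2 (0.55 log units; beyond the scatter), an at least 3.3-fold higher number from compound 2 to compound 3 (0.51 log units; beyond the scatter), and a step that the two limits leave unreadable from compound 1 to compound 3.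

Compound 4 `COc1ccc(NC(=O)COc2cc(C)nc3ccc(OC)cc23)c(OC)c1` differs from compound 3 by methoxy in place of hydrogen on an aromatic carbon. The one measured methoxy addition of the same kind, an at least 3.6-fold lower number from compound 1 to compound 2 (0.55 log units; beyond the scatter), lowered the number, whereas the methoxy of compound 3 left a limit; the bearing of these on compound 4 is mixed. A modest step downward is expected, an at least 1.7-fold lower number from compound 3 to compound 4 (0.24 log units; that floor lies within the scatter), and for compound 4 the estimate is 80000 nM, within 30000 nM to 160000 nM.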

Compound 4, half-maximal cytotoxic concentration: > 131000 nM
Compound 4: only a limit was reported; the forecaster's own chance of this, stated with the estimate: 45%; middle value at least 1.6-fold (0.21 log units) away from the limit.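

In this assay compound 4 gives > 131000 nM, a limit and not a number. Compound 3 also gives only a limit, so the step between compound 3 and compound 4 cannot be read. On these data alone, whether the added methoxy changes the tolerated concentration in this pair stays open.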